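Methyl for furan-2-yl on a series without separation so far

A few compounds are considered here, and "the series" means these few. Any claim that something is new, unique, unknown or untested is made for them only; others in the source may bear on it.

Compound 1 `CNc1ncnc2[nH]cc(Sc3cccs3)c12` gives 26200 nM in a functional assay on CEM-DNR cells (Homo sapiens), read by MTT assay, with a stated time of 3 days (a lower number here means a stronger inhibitor, a higher number a weaker inhibitor), and serves as the reference for the shared core. Compound 2 `Nc1ncnc2[nH]cc(Sc3cccs3)c12` gives 20300 nM and compound 3 `c1coc(-c2ncnc3[nH]cc(Sc4cccs4)c23)c1` gives 20800 nM in this assay as well. Compound 3 stands within the scatter of both other compounds: the steps reaching it are a 1.0-fold higher number from compound 2 to compound 3 (0.01 log units; within the scatter) and a 1.3-fold lower number from compound 1 to compound 3 (0.10 log units; within the scatter) and neither separates it from its neighbours. The remaining step among the three, a 1.3-fold lower number from compound 1 to compound 2 (0.11 log units; within the scatter), is also within the scatter.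

Compound 4 `Cc1ncnc2[nH]cc(Sc3cccs3)c12` carries methyl in place of furan-2-yl on an aromatic carbon next to the ring nitrogen, a change counted as methyl in place of furan-2-yl on an aromatic carbon and made at the carbon already varied in the series. The two steps at that carbon bear most directly on it: amino, methylamino and furan-2-yl have been exchanged there with a 1.0-fold higher number from compound 2 to compound 3 (0.01 log units; within the scatter) and a 1.3-fold lower number from compound 1 to compound 3 (0.10 log units; within the scatter) as the results. Among the compounds with values here, no measured compound carries methyl at that carbon, so the range is kept wider than the scatter.

No shift beyond the scatter is expected, and the estimated step is a 1.1-fold higher number from compound 3 to compound 4 (0.02 log units; within the scatter) in either direction of little note. Compound 4 is estimated at 22000 nM with an expected range from 10000 nM to 45000 nM in this assay for now.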

Compound 4, half-maximal inhibitory concentration: > 50000 nM
Compound 4: no number, only a limit; the forecaster's own chance of this, stated with the estimate: 10%; at least 2.2-fold (0.35 log units) between middle value and limit.
By their numbers in this assay, from the lowest: compounds 2, 3 and 1 (each within the scatter of the next). At a limit, above all of these: compound 4.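

Exchanges at this aromatic carbon now give a separation: an at least 2.4-fold higher number from compound 3 to compound 4 (0.38 log units; beyond the scatter) and an at least 2.4-fold higher number from compound 2 to compound 4 (0.39 log units; beyond the scatter) both lie beyond the scatter, whereas furan-2-yl, amino and methylamino there had stayed within the scatter of one another. The series therefore responds to the group at this carbon, but compound 1 goes against a clean split, since the floor of an at least 1.9-fold higher number from compound 1 to compound 4 (0.28 log units; that floor lies within the scatter) lies within the scatter and methyl cannot yet be separated from methylamino. In this assay, going by these compounds, compound 4 is reported only as a limit and not as a number, so the real size of all three steps is unknown and each gives only a floor: the limit of > 50000 nM in this assay, at which 1 of the 4 values shown sits.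

On these data alone, whether an ethyl chain, a methoxy group or a chlorine atom at this carbon would sit with compound 2 and compound 3 or reach the limit of compound 4 stays open, and so does what separates methyl from the other groups here. The compounds shown also share everything outside this carbon, so whether the same step holds with any other group elsewhere on the shared core is unknown.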